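The compounds below may be only part of what the source reports. "The series", "measured", "known", "first", "only" and "open" are said of these compounds alone.

Compound 1 `O=C(N1CCC=C[C@@H]1Cc1ccccc1)n1cc(-c2ccc(-c3ccccc3)cc2)nn1` gives 2.51 nM
Compound 2 `O=C(N1CCC=C[C@@H]1COCc1ccccc1)n1cc(-c2ccc(-c3ccccc3)cc2)nn1` gives 12.6 nM

In an assay on HEK293 cells for inhibition of Monoacylglycerol lipase ABHD6 (Homo sapiens), read by fluorescence (on this read-out higher numbers stand for weaker inhibition and lower numbers for stronger inhibition), compound 2 stands at the higher of the two numbers shown, with compound 1 the nearest at 2.51 nM. Going by the values given here, the only measured step, a 5.0-fold higher number from compound 1 to compound 2 (0.70 log units; beyond the scatter), concerns the group on the saturated ring.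

Compound 3 `O=C(N1CCC=C[C@@H]1COCc1ccccc1)n1cc(-c2ccccc2)nn1` differs from compound 2 by hydrogen in place of phenyl on an aromatic carbon. Among the compounds with values here, no measured step touches this ring, so nothing here directly sets the size of the change. Removing a whole aromatic ring is nevertheless expected to weaken inhibition: compound 3 is estimated at 200 nM, from 40 nM to 1000 nM. That would be a step of a 16-fold higher number from compound 2 to compound 3 (1.20 log units; beyond the scatter), beyond the scatter.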

Compound 3, half-maximal inhibitory concentration: 158 nM
Beside the measured number, compound 3's estimate is 1.3-fold (0.10 log units) above it; the measured number falls inside the stated range.
By their numbers in this assay, from the lowest: compound 1; then compound 2; then compound 3.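

The earlier compounds shown here changed only the side chain on the ring bearing the urea-like carbonyl, leaving the aromatic end of the molecule untouched. In this assay, removing the phenyl from the aromatic carbon para to a large group gives a 13-fold higher number from compound 2 to compound 3 (1.10 log units; beyond the scatter) and shows that this phenyl matters for inhibition when the benzyloxy side chain is present.

From the compounds shown here alone, whether a methyl group, a methoxy group or a pyridine ring could replace that phenyl stays open, as does whether its removal would cost as much with the side chain of compound 1. No measurement here accounts for the size of this loss.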